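The source may hold more compounds than are shown below. What is called first, only, known or untested is meant among the compounds shown, and "the series" means these compounds.

Of the compounds shown here, three from a series of related structures have been tested for their ability to slow the growth of a breast cancer cell line. Compound 1, `O=[N+]([O-])c1ccc(-c2nn(-c3ccccc3)cc2C(Nc2nc3ccccc3s2)c2c(O)ccc3ccccc23)cc1`, and compound 2, `COc1ccc2nc(NC(c3cn(-c4ccccc4)nc3-c3ccc([N+](=O)[O-])cc3)c3c(O)ccc4ccccc34)sc2c1`, share a core and differ only by hydrogen in place of methoxy on an aromatic carbon; in a functional assay on MCF7 cells (Homo sapiens) for antiproliferative activity, read by MTT assay, with a stated time of 48 h (on this read-out higher numbers stand for weaker inhibition and lower numbers for stronger inhibition), compound 1 gives 14700 nM while compound 2 gives 13300 nM, a step of a 1.1-fold higher number from compound 2 to compound 1 (0.04 log units; within the scatter). Compound 3, `COc1cccc(-c2nn(-c3ccccc3)cc2C(Nc2nc3ccc(OC)cc3s2)c2c(O)ccc3ccccc23)c1`, differs from compound 2 by 3-methoxyphenyl in place of 4-nitrophenyl on an aromatic carbon, and in this assay compound 3 gives 62600 nM, a step of a 4.7-fold higher number from compound 2 to compound 3 (0.67 log units; beyond the scatter).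

Compound 4, `COc1ccc2nc(NC(c3cn(-c4ccccc4)nc3-c3ccccc3)c3c(O)ccc4ccccc34)sc2c1`, has not yet been measured. It differs from compound 3 by hydrogen in place of methoxy on an aromatic carbon. This is the same kind of change as that from compound 2 to compound 1, but not the same: there the methoxy left a six-membered ring that is part of a fused system of two rings, meta to a fused ring and para to a fused ring, whereas here it leaves a ring that is meta to a large group. Because the earlier step was a 1.1-fold higher number from compound 2 to compound 1 (0.04 log units; within the scatter), a similar small step is expected here, estimated as a 1.0-fold higher number from compound 3 to compound 4 (0.02 log units; within the scatter), giving an expected value for compound 4 of 65000 nM, most likely between 30000 nM and 140000 nM.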

Compound 4, half-maximal inhibitory concentration: 40800 nM
Compound 4: the middle estimate sits 1.6-fold (0.20 log units) above what was measured; the measured number falls inside the stated range.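

Swapping methoxy for hydrogen on the 3-methoxyphenyl group gives a 1.5-fold lower number from compound 3 to compound 4 (0.19 log units; within the scatter), so in this assay this swap does not stand out from repeat measurement. Set beside the same swap on the other core, the two results agree: the same change on two cores in this assay, a 1.1-fold higher number (0.04 log units; within the scatter) from compound 2 to compound 1 and a 1.5-fold lower number (0.19 log units; within the scatter) from compound 3 to compound 4, 1.7-fold (0.23 log units) apart, within the scatter of two such steps

This shows that, in these two pairs, the swap could be carried from one core to the other with no step beyond the scatter, even though the methoxy leaves a different ring in each pair; it does not show that the same would hold on any other core or in any other assay, and the other swap at this site, hydrogen in place of nitro, gives a 3.1-fold higher number from compound 2 to compound 4 (0.49 log units; beyond the scatter), so what sits on that phenyl ring can matter.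

The compounds shown leave open how an amine or a carboxylic acid on that phenyl ring would read in this assay. They also leave open whether a longer chain in place of the methoxy would keep the step this small.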